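A few compounds are considered here, and "the series" means these few. Any claim that something is new, unique, unknown or untested is made for them only; others in the source may bear on it.

The series shares one core, seen in compound 1 `O=C(c1cn(-c2ccccc2)nc1-c1cccnc1)N1CCC(Cc2ccccc2)CC1`, compound 2 `COc1ccc(OC(=O)c2cn(-c3ccccc3)nc2-c2cccnc2)cc1` and compound 3 `COc1ccc(OC(=O)c2cn(-c3ccccc3)nc2-c2ccncc2)cc1`. In a functional assay on MDA-MB-231 cells (Homo sapiens) for cytotoxicity, read by MTT assay, with a stated time of 48 h (a higher number here means a weaker inhibitor, a lower number a stronger inhibitor), compound 1 gives > 100000 nM, which is a limit of the assay rather than a number. Compound 2 gives > 100000 nM, again a limit. Compound 3 gives > 100000 nM, also a limit. The step that the two limits leave unreadable from compound 2 to compound 3 cannot be read, since both of its ends rest at the limit of > 100000 nM in this assay, at which 3 of the 3 values shown sit. Compound 3 thus stands at the limit, and nothing in the numbers separates it from the other two.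

Compound 4 `Cc1ccc(C(C)C)c(OC(=O)c2cn(-c3ccccc3)nc2-c2ccncc2)c1` differs from compound 3 by 2-isopropyl-5-methylphenyl in place of 4-methoxyphenyl on an oxygen next to a carbonyl group. For the measured compounds named here, no measured step touches this exchange on the oxygen next to the carbonyl group; the only step measured, a step that the two limits leave unreadable from compound 2 to compound 3, concerns the pyridin-3-yl to pyridin-4-yl change and is itself unreadable. Going by the values given here, every value so far sits at the limit of > 100000 nM in this assay, at which 3 of the 3 values shown sit, so no direction can be drawn from the data. The step of a number no higher from compound 3 to compound 4 (the limit leaves the size open) is therefore expected to be none that the assay can resolve. Compound 4 is expected to give 100000 nM, within a range from 30000 nM to 300000 nM, and most probably to be reported once more only as a limit.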

Compound 4, half-maximal inhibitory concentration: > 100000 nM
Compound 4 was reported as a limit (the forecaster's own chance of this, stated with the estimate: 80%); the middle value lies on the limit itself.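

Compound 3 and compound 4 are both reported in this assay only as limits, so the step between them, 2-isopropyl-5-methylphenyl in place of 4-methoxyphenyl, cannot be read: the limit of > 100000 nM in this assay, at which 4 of the 4 values shown sit.

The compounds shown leave open what value any of them would reach in this assay and whether any exchange on the shared core changes it.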